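The compounds below may be only part of what the source reports. "The series", "measured", "known", "first", "only" and "open" are said of these compounds alone.

Measured compounds:
- compound 2, `NCCCc1ccc(-c2ccc(-c3ccc(CCCN)s3)s2)s1`: in an ADME assay on MDCK cells (Canis lupus familiaris) for cytotoxicity, read by MTT assay, with a stated time of 2 days (on this read-out higher numbers stand for lower toxicity in this test and lower numbers for higher toxicity in this test), compound 2 gives > 200000 nM, which is a limit of the assay, not a number.
- compound 1, `BrCCCCc1ccc(-c2ccc(-c3ccc(-c4ccc(CCCCBr)s4)s3)s2)s1`: compound 1 stands at "not determined" (no result reported) in this assay.
- compound 3, `BrCCCCc1ccc(CCCCBr)s1`: compound 3 stands at "not determined" (no result reported) in this assay.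

Compound 2 is thus the only entry with any read-out, and that is only a limit, matching (the limit of > 200000 nM in this assay, at which 1 of the 3 values shown sits); the other two entries carry no single number. Compound 4, `NCCCc1ccc(-c2ccc(-c3cccs3)s2)s1`, differs from compound 2 by hydrogen in place of 3-aminopropyl on an aromatic carbon. Within the data shown here, no step between measured compounds exists to calibrate this change, so the step is expected to be none beyond the usual scatter, perhaps a slight move toward higher toxicity. Compound 4 is expected at 180000 nM, range 70000 nM to 300000 nM, meaning an expected step of an at least 1.1-fold lower number from compound 2 to compound 4 (0.04 log units; that floor lies within the scatter).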

Compound 4, half-maximal cytotoxic concentration: 18900 nM
Compound 4: middle estimate off by 9.5-fold (0.98 log units), on the high side; the measured number lies below the stated range.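

In this assay, among these compounds, hydrogen in place of 3-aminopropyl on an aromatic carbon, next to the ring sulfur, gives an at least 10-fold lower number from compound 2 to compound 4 (1.02 log units; beyond the scatter) as the first readable step. At this position, the 3-aminopropyl group and hydrogen are therefore not interchangeable in this test. The size of the step is only a floor, because compound 2 stands at a limit of the assay, not at a number: the limit of > 200000 nM in this assay, at which 1 of the 4 values shown sits.

As far as these compounds go, whether the step belongs to the terminal amine or to the propyl chain remains open. A terminal hydroxyl, a carboxylic acid or a shorter chain at this position would separate the two.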